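Series notes: aryl exchange from compound 3 to compound 4

The source may report more compounds than this note shows. Statements on the series, on what has been measured and on what is new or still open speak of the compounds shown alone.

Of the compounds shown here, three of the shared core have been measured in an ADME assay on HUVEC cells (Homo sapiens) for cytotoxicity, read by MTT assay, with a stated time of 48 h; a higher number here means a weaker inhibitor, a lower number a stronger inhibitor. Compound 1 `Nc1nc(-c2ccc(Cl)cc2)cn1/N=C/c1cc2ccccc2nc1Cl` gives 28000 nM. Compound 2 `Cc1ccc2nc(Cl)c(/C=N/n3cc(-c4ccccc4)nc3N)cc2c1` gives 41500 nM. Compound 3 `Cc1ccc2nc(Cl)c(/C=N/n3cc(-c4ccc(Cl)cc4)nc3N)cc2c1` gives 38500 nM. Compound 3 stands second highest of the three numbers, with compound 2 nearest and compound 1 furthest; both gaps are within the scatter, so no order among the three can be read from them. The two steps into compound 3 are a 1.4-fold higher number from compound 1 to compound 3 (0.14 log units; within the scatter) and a 1.1-fold lower number from compound 2 to compound 3 (0.03 log units; within the scatter), neither of them beyond the scatter.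

Compound 4 `Cc1ccc2nc(Cl)c(/C=N/n3cc(-c4cccc5ccccc45)nc3N)cc2c1` is not yet measured. It differs from compound 3 in one place: naphthalen-1-yl in place of 4-chlorophenyl on an aromatic carbon. Among the compounds with values here, no measured step exchanges one aromatic group for another at this place; the nearest measured change is that from compound 2 to compound 3, which alters the same 4-chlorophenyl group and stays within the scatter. Nothing in the measured steps points to a step beyond the scatter in this assay, in either direction. The expected step of a 1.0-fold lower number from compound 3 to compound 4 (0.01 log units; within the scatter) is therefore small. Compound 4 is estimated at 38000 nM, with a range from 15000 nM to 90000 nM.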

Compound 4, half-maximal inhibitory concentration: 9580 nM
Compound 4: middle estimate off by 4.0-fold (0.60 log units), on the high side; measured number below the stated range.
By their numbers in this assay, from the lowest: compound 4; then compounds 1, 3 and 2 (each within the scatter of the next).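

In this assay, the aromatic group on this carbon of the five-membered aromatic ring is the only place among the compounds shown where a single exchange carries the number beyond the scatter: naphthalen-1-yl in place of 4-chlorophenyl gives a 4.0-fold lower number from compound 3 to compound 4 (0.60 log units; beyond the scatter), and naphthalen-1-yl in place of phenyl gives a 4.3-fold lower number from compound 2 to compound 4 (0.64 log units; beyond the scatter). Adding chloro to the phenyl group at this same place stayed within the scatter (a 1.1-fold lower number from compound 2 to compound 3 (0.03 log units; within the scatter)), so this position tolerated that small change without a readable shift, whereas replacing the single six-membered aromatic ring with the two-ring naphthalen-1-yl group produced a modest shift from either starting compound. Nothing measured here gives a reason for this step.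

As far as these compounds go, it remains open whether the lower number depends on the second aromatic ring itself or on how that ring is attached, a question that naphthalen-2-yl or biphenyl-4-yl at the same carbon would help to separate. Also open, from the compounds shown here alone, are whether a cyclohexyl group or a pyridine ring would keep the step, and whether naphthalen-1-yl would give a similar step on the core of compound 1.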